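The source may hold more compounds than are shown below. What is called first, only, known or untested is meant among the compounds shown, and "the series" means these compounds.

Measured compounds:
compound 1 `CN(Cc1ccc(OCCCNC(=N)N)cc1)c1nc2ccc(Oc3ccc(C(F)(F)F)cc3)cc2s1`, in an assay on cells for inhibition of Voltage-dependent T-type calcium channel subunit alpha-1H (Homo sapiens), read by FLIPR and calcium flux, with stated times of 600 s and 300 s (on this read-out lower numbers stand for stronger inhibition and higher numbers for weaker inhibition), compound 1 gives 212000 nM
compound 2 `N=C(N)NCCCOc1ccc(CNc2nc3ccc(Oc4ccc(F)cc4)cc3s2)cc1`, in this assay compound 2 gives 288000 nM

Both compounds share a core and differ in their outer groups; the numbers of compound 2 and compound 1 lie within the usual scatter of each other, so neither can be called the stronger. Compound 3 `N=C(N)NCCCOc1ccc(CNc2nc3ccc(Oc4ccc(C(F)(F)F)cc4)cc3s2)cc1` is not yet measured. It arises from compound 2 by trifluoromethyl in place of fluoro on an aromatic carbon. Within the data shown here, no step between measured compounds isolates this change, so the step from compound 2 to compound 3 is expected to be small, a 1.3-fold lower number from compound 2 to compound 3 (0.12 log units; within the scatter), possibly not beyond the scatter, because compound 1, which also carries trifluoromethyl, gives 212000 nM. Compound 3 is therefore estimated at 220000 nM, within 100000 nM to 450000 nM.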

Compound 3, half-maximal inhibitory concentration: 195000 nM
Compound 3: the middle estimate sits 1.1-fold (0.05 log units) above what was measured, within the range that was stated.
By their numbers in this assay, from the lowest: compounds 3, 1 and 2 (each within the scatter of the next).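

In this assay trifluoromethyl in place of fluoro on this aromatic carbon gives a 1.5-fold lower number from compound 2 to compound 3 (0.17 log units; within the scatter) and stays within the scatter, so the two groups cannot be told apart at this position. Hydrogen in place of methyl on the nitrogen gives a 1.1-fold lower number from compound 1 to compound 3 (0.04 log units; within the scatter) and also stays within the scatter, so these two compounds cannot be told apart either. No measurement here explains why these changes leave the number within the scatter.

Going by these compounds, whether a nitrile or a carboxylic acid at this aromatic carbon would give a step beyond the scatter remains open. The same question stands for an ethyl group or a longer chain on the nitrogen.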